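A few compounds are considered here, and "the series" means these few. Any claim that something is new, unique, unknown or untested is made for them only; others in the source may bear on it.

In a functional assay on CEM-DNR-bulk cells (Homo sapiens), read by MTT assay, with a stated time of 72 h (on this read-out lower numbers stand for stronger inhibition and higher numbers for weaker inhibition), compound 1 (`CNc1ncnc2c1c(-c1cc3ccccc3o1)cn2[C@@H]1O[C@H](CO)[C@@H](O)[C@H]1O`) gives > 20000 nM as a limit of the assay. Compound 2 (`Nc1nc(N)c2c(-c3ccco3)cn([C@@H]3O[C@H](CO)[C@@H](O)[C@H]3O)c2n1`) gives > 20000 nM as a limit too. Compound 3 (`COc1nc(N)nc2c1c(-c1ccco1)cn2[C@@H]1O[C@H](CO)[C@@H](O)[C@H]1O`) gives > 20000 nM as a limit and not a number. For the measured compounds named here, the series so far reads as the limit of > 20000 nM in this assay, at which 3 of the 3 values shown sit, and holds no readable value, so compound 3 has no rank among the others.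

Compound 4 (`C#Cc1cn([C@@H]2O[C@H](CO)[C@@H](O)[C@H]2O)c2nc(N)nc(OC)c12`) differs from compound 3 by ethynyl in place of furan-2-yl on an aromatic carbon so that the furan-2-yl ring leaves and a triple bond enters. Going by the values given here, the only measured step is a step that the two limits leave unreadable from compound 2 to compound 3 and it is a different exchange that gives no size to carry over. Among the compounds with values here, no measured pair removes furan-2-yl, so the size of this change rests on no direct precedent.

Compound 3 stands at > 20000 nM as a limit, so any readable change in this assay can only run toward stronger inhibition. Compound 4 may equally stay at the limit. The estimated change is an at least 2.5-fold lower number from compound 3 to compound 4 (0.39 log units; beyond the scatter) with wide uncertainty and is expected to be modest at best. For compound 4 the estimate is 8000 nM with an expected range from 800 nM to 20000 nM on present data.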

Compound 4, half-maximal inhibitory concentration: > 20000 nM
Compound 4 gave a limit, no number; the forecaster's own chance of this, stated with the estimate: 50%; at least 2.5-fold (0.39 log units) between middle value and limit.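

In this assay compound 4 gives > 20000 nM, a limit and not a number. No step can be read from compound 3 to compound 4, so the series still offers no readable step: the limit of > 20000 nM in this assay, at which 4 of the 4 values shown sit.

The compounds shown leave open whether any change on the shared core gives a readable value in this assay.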